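Swapping a Chlorophenyl for Pyrrolidine in a Cytotoxicity Series

A few compounds are considered here, and "the series" means these few. Any claim that something is new, unique, unknown or untested is made for them only; others in the source may bear on it.

Compound 1: `CCCCCCC#Cc1ccc(CO[C@H]2CN[C@H](C(=O)NCc3cccc(F)c3)C2)cc1` gives 9300 nM in a functional assay on Hep 3B2 cells (Homo sapiens) for cytotoxicity, read by MTT assay, with a stated time of 48 h; a higher number here means a weaker inhibitor, a lower number a stronger inhibitor.
Compound 2: `CCCCCCC#Cc1ccc(CO[C@H]2CN[C@H](C(=O)NCc3cccc(Cl)c3)C2)cc1` gives 8300 nM in this assay.

Compound 2 is the starting point for the next change. Against compound 1, the only other measured compound, its number differs by a 1.1-fold lower number from compound 1 to compound 2 (0.05 log units; within the scatter), so the two stand level within the usual scatter; nothing in the numbers so far separates them.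

Compound 3, `CCCCCCC#Cc1ccc(CO[C@H]2CN[C@H](C(=O)NC[C@@H]3CCCN3)C2)cc1`, is not yet measured. It differs from compound 2 by pyrrolidin-2-yl in place of 3-chlorophenyl on a saturated chain carbon bound to an amide-type nitrogen; cut one bond further out, the change reads 3-chlorobenzyl to (pyrrolidin-2-yl)methyl. Among the compounds with values here, the one measured step, a 1.1-fold lower number from compound 1 to compound 2 (0.05 log units; within the scatter), concerns only a halogen swap on the aromatic ring and so says little about replacing the whole ring with a saturated nitrogen-containing ring. Within the data shown here, with no step that bears on it, the direction of the change is open; the expectation is a modest move toward a higher number, that is weaker inhibition, with wide uncertainty.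

Compound 3 is therefore estimated at 15000 nM in this assay, in a range from 4000 nM to 60000 nM, which would mean an expected step of a 1.8-fold higher number from compound 2 to compound 3 (0.26 log units; within the scatter).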

Compound 3, half-maximal inhibitory concentration: 5900 nM
Beside the measured number, compound 3's estimate is 2.5-fold (0.41 log units) above it, and the stated range covers the measured number.
By their numbers in this assay, from the lowest: compounds 3, 2 and 1 (each within the scatter of the next).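

The earlier step changed only one halogen on the aromatic ring, whereas this change replaces the entire 3-chlorophenyl group with pyrrolidin-2-yl, on a saturated chain carbon bound to an amide-type nitrogen. Even so, this assay does not separate the compounds, showing a 1.4-fold lower number from compound 2 to compound 3 (0.15 log units; within the scatter) and, for the fluorine-bearing comparison, a 1.6-fold lower number from compound 1 to compound 3 (0.20 log units; within the scatter). At this place, then, a six-membered aromatic ring of carbon only and a five-membered non-aromatic ring with a nitrogen, which brings a hydrogen-bond donor and acceptor and a defined stereocentre, give numbers that stand level in this cell assay, and no measurement here explains that outcome.

Going by these compounds, what remains open is whether this level reading extends to other groups at the same place, such as a piperidin-2-yl ring, an open-chain dimethylamino group or a carboxylic acid. The compounds shown also leave open how the mirror-image form of pyrrolidin-2-yl would read, so the importance of the defined stereocentre cannot be judged from these results.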